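Extending the Side Chain of a Purine Glycinamide

The compounds below may be only part of what the source reports. "The series", "measured", "known", "first", "only" and "open" are said of these compounds alone.

Three compounds share a core in which a cyclopropyl-substituted glycine amide hangs from a purine and is coupled to an amino acid ester. Compound 1 `NC(=O)CC[C@H](NC(=O)CN(c1ncnc2c1ncn2C1CCCCO1)C1CC1)C(=O)OCc1ccccc1` carries a glutamine-derived side chain ending in a carbamoyl group. Compound 2 `CC(C)[C@H](NC(=O)CN(c1nc(Cl)nc2[nH]cnc12)C1CC1)C(=O)OCc1ccccc1` bears an isopropyl side chain and a chloro-substituted core, and compound 3 `NC(=O)C[C@H](NC(=O)CN(c1nc(Cl)nc2[nH]cnc12)C1CC1)C(=O)O` pairs an asparagine-derived side chain with a free acid.

In a functional assay on the whole organism (Tail, strain ICR) with Mus musculus as the target, in the tail flick test, with a stated time of 150 min, at a dose of 25 umol/kg by the oral route (a lower number here means a weaker effect, a higher number a stronger effect of the compound at the dose given), compound 1 gives 10.7%. In this assay compound 2 gives 17.9%, and compound 3 gives 7.51%. Compound 1 sits between the numbers of compound 2 and compound 3, and both gaps are within the scatter of the method, so the three numbers cannot be ranked.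

Compound 4 `CC(C)(C)OC(=O)NCCCC[C@H](NC(=O)CN(c1ncnc2c1ncn2C1CCCCO1)C1CC1)C(=O)OCc1ccccc1` differs from compound 1 in one place: 2-((tert-butoxycarbonyl)amino)ethyl in place of carbamoyl on a saturated chain carbon, three bonds along the chain from an amide-type nitrogen and a carbonyl carbon. For the measured compounds named here, no measured pair in this set isolates a change of this kind, so nothing measured here sets the direction of the step. With all three measured numbers within the scatter of one another, the expected step from compound 1 to compound 4 is a number 1.3 percentage points higher from compound 1 to compound 4 (within the scatter), that is, none beyond the scatter. Compound 4 is therefore estimated at 12%, within a range of 3% to 25%.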

Compound 4, a percentage reported as activity, at one dose (the size of the read-out at that dose, not a potency): 17.2%
Compound 4: middle estimate off by 5.2 percentage points, on the low side; low and high end bracket the measured number.
By their numbers in this assay, from the lowest: compounds 3, 1, 4 and 2 (each within the scatter of the next, the first and the last beyond it).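

For the compounds shown here, the first single-place comparison in this set replaces carbamoyl with 2-((tert-butoxycarbonyl)amino)ethyl on a saturated chain carbon, three bonds along the chain from an amide-type nitrogen and a carbonyl carbon. In this assay this gives a number 6.5 percentage points higher from compound 1 to compound 4 (within the scatter), so the read-out does not separate compound 1 from compound 4. The position therefore accepts a group with many more heavy atoms, one that brings a carbamate in place of a primary amide, without a difference that can be told from the scatter at this dose. Nothing in the data offers an explanation for this result.

Going by these compounds, with one step at this position and that step within the scatter, the direction of any effect of the side chain stays open, and so does whether the tert-butoxycarbonyl group or the longer chain matters more. A free primary amine or a carboxylic acid at the end of the same chain, or a plain longer alkyl chain, would help to separate these two parts of the change.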